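Trifluoromethyl replacing hydrogen on the phenyl of compound 2

The source may hold more compounds than are shown below. What is called first, only, known or untested is meant among the compounds shown, and "the series" means these compounds.

Compound 2 `O=C1COc2ccc(-c3[nH]c(-c4ccccc4)nc3-c3ccccc3)cc2N1` holds the higher of two values in a functional assay on DLD-1 cells (Homo sapiens) for cytotoxicity, read by colorimetric assay and MTT assay, with a stated time of 3 days, tested at 1 uM (a higher number here means a weaker effect of the compound at the concentration tested, a lower number a stronger effect), where compound 2 gives 98.2%, with compound 1 `COc1ccc(-c2nc(-c3ccccc3)c(-c3ccc4c(c3)NC(=O)CO4)[nH]2)cc1` nearest at 96%, a gap within the scatter. Compound 3 `O=C1COc2ccc(-c3[nH]c(-c4ccc(C(F)(F)F)cc4)nc3-c3ccccc3)cc2N1` carries trifluoromethyl in place of hydrogen on an aromatic carbon. Going by the values given here, the only measured step, a number 2.2 percentage points higher from compound 1 to compound 2 (within the scatter), also exchanged a group on an aromatic carbon and stayed within the scatter, so a step of similar smallness is expected here: a number 4.2 percentage points lower from compound 2 to compound 3 (within the scatter). Compound 3 is therefore estimated at 94%, within 78% to 102%.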

Compound 3, a percentage reported as activity, at one concentration (the size of the read-out at that concentration, not a potency): 95%
Compound 3: the middle estimate sits 1 percentage points below what was measured; the measured number falls inside the stated range.
By their numbers in this assay, from the lowest: compounds 3, 1 and 2 (each within the scatter of the next).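

In this assay, placing trifluoromethyl on the phenyl, para to a large group, gives a number 3.2 percentage points lower from compound 2 to compound 3 (within the scatter), so this position tolerates a trifluoromethyl with no step beyond the scatter. Against methoxy at the same place, the exchange gives a number 1 percentage points lower from compound 1 to compound 3 (within the scatter), so hydrogen, methoxy and trifluoromethyl cannot be told apart here at this single concentration. Nothing measured here speaks to why the change leaves the read-out within the scatter. On these data alone, whether an amine or a carboxylic acid on this carbon would move the read-out beyond the scatter remains open.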